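Methyl in place of phenyl on the shared core

A few compounds are considered here, and "the series" means these few. Any claim that something is new, unique, unknown or untested is made for them only; others in the source may bear on it.

Compound 1 `O=C(NC1CCCCCC1)c1c(-c2ccccc2)c(Br)cn(Cc2ccc(F)cc2)c1=O` stands in an assay on HEK293 cells for inhibition of Lysophosphatidylserine lipase ABHD12 (Homo sapiens), with stated times of 30 min and 5 min (on this read-out higher numbers stand for weaker inhibition and lower numbers for stronger inhibition), only as a limit of the assay: compound 1 gives > 10000 nM. Compound 2 `O=C(NC1CCCCCC1)c1c(-c2ccccc2)c(-c2ccccc2)cn(Cc2ccc(F)cc2)c1=O` also sits at a limit, giving > 10000 nM in this assay. The step that the two limits leave unreadable from compound 1 to compound 2 cannot be sized. Compound 3 `Cc1c(Br)cn(Cc2ccc(F)cc2)c(=O)c1C(=O)NC1CCCCCC1` differs from compound 1 by methyl in place of phenyl on an aromatic carbon. Going by the values given here, no measured step bears on this change, because of the limit of > 10000 nM in this assay, at which 2 of the 2 values shown sit. For compound 3 a step that the limit leaves unreadable from compound 1 to compound 3 is expected, most likely again a limit rather than a number. Compound 3 is estimated at 20000 nM, within a range from 5000 nM to 100000 nM.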

Compound 3, half-maximal inhibitory concentration: 2100 nM
The estimate for compound 3 lay 9.5-fold (0.98 log units) above the measured number; measured number below the stated range.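

Methyl on this aromatic carbon, opposite the ring nitrogen, gives the first reading in this assay that is a number and not a limit, with an at least 4.7-fold lower number from compound 1 to compound 3 (0.67 log units; beyond the scatter). A single methyl in place of the six-carbon phenyl therefore keeps measurable inhibition at this position, which the compounds at the limit could not show: the limit of > 10000 nM in this assay, at which 2 of the 3 values shown sit.

From the compounds shown here alone, the true size of the step stays open, since compound 1 gives only a limit. Also open, going by these compounds, is whether ethyl, cyclopropyl or an amine on this carbon would give a lower or a higher number than methyl.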